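Sulfonyl for sulfanyl in a hydroxyphenyl amide series

The source may hold more compounds than are shown below. What is called first, only, known or untested is meant among the compounds shown, and "the series" means these compounds.

Measured so far:
compound 1 `O=C(Nc1ccc([N+](=O)[O-])c(C(F)(F)F)c1)c1ccc(Sc2ccc(O)cc2)cc1`, 5190 nM
compound 2 `O=C(Nc1cc(C(F)(F)F)cc(C(F)(F)F)c1)c1ccc(Sc2ccc(O)cc2)cc1`, 2590 nM
compound 3 `O=C(Nc1ccc([N+](=O)[O-])c(C(F)(F)F)c1)c1ccc(S(=O)(=O)c2ccc(O)cc2)cc1`, 8570 nM

All three were run in a functional assay on VCaP cells (Homo sapiens) for antiproliferative activity, read by fluorescence and propidium iodide staining, with a stated time of 96 h; on this read-out higher numbers stand for weaker inhibition and lower numbers for stronger inhibition. Compound 2 has the lowest number of the three; its gap to compound 1 is within the scatter, its gap to compound 3 beyond it. How the core of compound 1 differs from the core of compound 2 is not broken down here.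

One change recurs. From compound 1 to compound 3 it is (4-hydroxyphenyl)sulfonyl in place of (4-hydroxyphenyl)sulfanyl on an aromatic carbon, and in this assay it gave a 1.7-fold higher number from compound 1 to compound 3 (0.22 log units; within the scatter). The unmeasured compound 4 `O=C(Nc1cc(C(F)(F)F)cc(C(F)(F)F)c1)c1ccc(S(=O)(=O)c2ccc(O)cc2)cc1` is made from compound 2 by the same change, ((4-hydroxyphenyl)sulfonyl in place of (4-hydroxyphenyl)sulfanyl on an aromatic carbon), at the same kind of place.

For the measured compounds named here, on that single precedent, the step from compound 2 to compound 4 in this assay is expected to be about a 1.7-fold higher number from compound 2 to compound 4 (0.23 log units; within the scatter), a small loss comparable to the one seen from compound 1 to compound 3, resting on compound 2 at 2590 nM. Compound 4 is therefore estimated at 4400 nM, likely between 2000 nM and 10000 nM.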

Compound 4, half-maximal inhibitory concentration: 9720 nM
Compound 4: middle estimate off by 2.2-fold (0.34 log units), on the low side; the range from low to high includes it.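

In this assay, (4-hydroxyphenyl)sulfonyl in place of (4-hydroxyphenyl)sulfanyl gives a 3.8-fold higher number from compound 2 to compound 4 (0.57 log units; beyond the scatter), so on this core the change costs inhibition by a margin that can be read as real. Set beside the earlier step, the size of the change does not separate between the two cores, and the series so far gives no ground for treating it as core-dependent: the same change on two cores in this assay, a 1.7-fold higher number (0.22 log units; within the scatter) from compound 1 to compound 3 and a 3.8-fold higher number (0.57 log units; beyond the scatter) from compound 2 to compound 4, 2.3-fold (0.36 log units) apart, within the scatter of two such steps. For the compounds shown here, this supports carrying the change between these two cores as a shift of similar size, but it does not show that the step is the same on both, since only one of the two steps clears the scatter, and two pairs say nothing about any further core.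

On these data alone, whether a sulfinyl, an ether oxygen or a methylene in place of the sulfur would track the sulfanyl or the sulfonyl compounds remains open. So does the effect of replacing the hydroxyl with a methoxy or an amine on either core.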